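Fluoro to trifluoromethyl on the aryl urea end

The source may hold more compounds than are shown below. What is called first, only, known or untested is meant among the compounds shown, and "the series" means these compounds.

Going by the values given here, in a functional assay on MIA PaCa-2 cells (Homo sapiens) for inhibition, read by MTT assay, with a stated time of 72 h (on this read-out higher numbers stand for weaker inhibition and lower numbers for stronger inhibition), compound 2 `COc1cc(NC(C)CCCNC(=O)NNC(=O)Nc2cccc(F)c2)c2ncccc2c1` gives 69000 nM, the only actual number so far. Compound 1 `COc1cc(NC(C)CCCNC(=O)NNC(=O)Nc2ccc(F)cc2)c2ncccc2c1` gives only a limit, >= 250000 nM. Compound 3 `COc1cc(NC(C)CCCNC(=O)NNC(=O)Nc2cccc(C(F)(F)F)c2)c2ncccc2c1` carries trifluoromethyl in place of fluoro on an aromatic carbon, (trifluoromethyl in place of fluoro on an aromatic carbon). Among the compounds with values here, the only measured step, an at least 3.6-fold lower number from compound 1 to compound 2 (0.55 log units; beyond the scatter), is 3-fluorophenyl in place of 4-fluorophenyl, a different change, so it bears only loosely and sets no firm size. A modest move to a lower number in this assay is expected, a 2.0-fold lower number from compound 2 to compound 3 (0.29 log units; within the scatter). The estimate for compound 3 is 35000 nM, with an expected range of 9000 nM to 130000 nM.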

Compound 3, half-maximal inhibitory concentration: 5600 nM
The estimate for compound 3 lay 6.3-fold (0.80 log units) above the measured number; the whole stated range lies above it.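

Exchanging fluoro for trifluoromethyl at the same place, on an aromatic carbon meta to a large group, gives a 12-fold lower number from compound 2 to compound 3 (1.09 log units; beyond the scatter) in this assay, so the identity of the group matters here, not only where it sits. The full change from the 4-fluorophenyl end reads an at least 44-fold lower number from compound 1 to compound 3 (1.64 log units; beyond the scatter). Compound 1 is a limit of the assay, not a number: the limit of >= 250000 nM in this assay, at which 1 of the 3 values shown sits.

Going by these compounds, whether a chloro, methyl or nitrile group at the same place gives a step of similar size stays open. So does whether the exchange holds with a longer chain in the linker.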